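The source may report more compounds than this note shows. Statements on the series, on what has been measured and on what is new or still open speak of the compounds shown alone.

Measured in a physicochemical assay for lipophilicity, using the shake flask method; a higher number here means a more lipophilic compound, a lower number a more polar compound:
Compound 1 `C[C@H](Oc1ccc2ncc(CCC(=O)O)c(C3CC3)c2c1)c1c(Cl)ccc(F)c1Cl`: 4.1
Compound 2 `C[C@H](Oc1ccc2ncc(/C=C/S(=O)(=O)O)c(C3CC3)c2c1)c1c(Cl)ccc(F)c1Cl`: 2.5

Compound 1 stands higher of the two, at 4.1, and compound 2 gives 2.5, a clear drop. The next compound to be measured, compound 3 `C[C@H](Oc1ccc2nc(OCCN)c(CCC(=O)O)c(C3CC3)c2c1)c1c(Cl)ccc(F)c1Cl`, keeps the core and the 2-carboxyethyl group of compound 1 and differs from it in one place: 2-aminoethoxy in place of hydrogen on an aromatic carbon. The 2-aminoethoxy group replaces hydrogen on an aromatic carbon next to the ring nitrogen, ortho to the 2-carboxyethyl group.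

Within the data shown here, only one measured step is available as a guide: a number 1.60 log units lower from compound 1 to compound 2 (beyond the scatter). Among the measured compounds shown here, that large step replaces a different group, so it bears on the new change only loosely, and no measured step shows a change at this place. Taking it as the sole precedent, a downward step of moderate size, beyond the scatter, is expected in this assay, probably somewhat smaller than that drop. The estimated change is a number 1.10 log units lower from compound 1 to compound 3 (beyond the scatter). For compound 3 the expected value is 3, with an estimated range of 2.2 to 3.7.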

Compound 3, distribution coefficient: 3.8
The estimate for compound 3 lay 0.80 log units below the measured number; measured number above the stated range.
By their numbers in this assay, from the lowest: compound 2; then compounds 3 and 1 (each within the scatter of the next).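

In this assay, 2-aminoethoxy in place of hydrogen on the aromatic carbon next to the ring nitrogen, ortho to a 2-carboxyethyl group, gives a number 0.30 log units lower from compound 1 to compound 3 (within the scatter). This is the first step shown at this position, and it shows that the shared core can take this chain here with a reading that cannot be told apart from that of compound 1, whereas the earlier step, which exchanged the group on a different aromatic carbon, was a number 1.60 log units lower from compound 1 to compound 2 (beyond the scatter). Nothing given here accounts for the two numbers lying within the scatter of each other.

Going by these compounds, it remains open whether this result belongs to the 2-aminoethoxy group as a whole or would hold equally for a simple methoxy group, a longer chain ending in an amine, or a chain ending in a carboxylic acid at the same position. Among these compounds, it is also open whether the 2-aminoethoxy group would give a similarly small step on the core of compound 2, since the one step at this position rests on the core of compound 1 alone.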